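Swapping an amide-bearing aryl for a fused bicyclic ring

A few compounds are considered here, and "the series" means these few. Any claim that something is new, unique, unknown or untested is made for them only; others in the source may bear on it.

Compound 3 `NC(=O)c1cccc(-c2cc(C(O)(C(F)(F)F)C(F)(F)F)cnc2N2CCN(S(=O)(=O)c3ccc(N)nc3)CC2)c1` sits in the middle of three compounds measured in an ADME assay (liver) for metabolic stability, with Liver microsome (Rattus norvegicus) as the target, using microsomes and NADPH, with a stated time of 30 min, tested at 1 uM (a lower number here means slower removal, a higher number faster removal of the compound), where compound 3 gives 63 mL.min-1.g-1. Compound 1 `CC(C)(O)C#Cc1cc(C(O)(C(F)(F)F)C(F)(F)F)cnc1N1CCN(S(=O)(=O)c2ccc(N)nc2)CC1` gives 16 mL.min-1.g-1 in this assay, and compound 2 `CC(C)(C)n1cc(-c2cc(C(O)(C(F)(F)F)C(F)(F)F)cnc2N2CCN(S(=O)(=O)c3ccc(N)nc3)CC2)cn1` gives 459 mL.min-1.g-1. Compound 1 thus shows the lowest number and compound 2 the highest, with a 3.9-fold higher number from compound 1 to compound 3 (0.60 log units; beyond the scatter) and a 7.3-fold lower number from compound 2 to compound 3 (0.86 log units; beyond the scatter) both beyond the scatter.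

Compound 4 `Cc1nc2cc(-c3cc(C(O)(C(F)(F)F)C(F)(F)F)cnc3N3CCN(S(=O)(=O)c4ccc(N)nc4)CC3)ccc2o1` differs from compound 3 in one place: 2-methyl-1,3-benzoxazol-5-yl in place of 3-carbamoylphenyl on an aromatic carbon. Both earlier steps changed the same aromatic position and both moved the read-out by a modest to large amount, so this change is likely to matter. The group entering keeps an aromatic six-membered carbon ring but adds a fused five-membered ring and drops the hydrogen-bond donor of the carbamoyl group; the nearest measured analogue in character, compound 2, carries a heteroaromatic ring and gives the highest number, while compound 3 with its amide gives a lower one. The account therefore expects compound 4 to move upward, with an estimated step of a 2.1-fold higher number from compound 3 to compound 4 (0.31 log units; beyond the scatter), though with wide uncertainty. The estimate for compound 4 in this assay is 130 mL.min-1.g-1, within a range from 45 mL.min-1.g-1 to 380 mL.min-1.g-1.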

Compound 4, intrinsic clearance in microsomes: 99 mL.min-1.g-1
The estimate for compound 4 lay 1.3-fold (0.12 log units) above the measured number, and the stated range covers the measured number.
By their numbers in this assay, from the lowest: compound 1; then compounds 3 and 4 (each within the scatter of the next); then compound 2.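

Compound 4 shows that at this position, ortho to a large group, the 3-carbamoylphenyl group can give way to 2-methyl-1,3-benzoxazol-5-yl, losing the hydrogen-bond donor of the carbamoyl group and gaining a fused five-membered ring, with only a 1.6-fold higher number from compound 3 to compound 4 (0.20 log units; within the scatter) in this assay. The two six-membered aromatic carbon ring groups thus form a middle level, apart from both earlier extremes: the step from the 1-(tert-butyl)-1H-pyrazol-4-yl group is a 4.6-fold lower number from compound 2 to compound 4 (0.67 log units; beyond the scatter), and the step from the 3-hydroxy-3-methylbut-1-yn-1-yl group is a 6.2-fold higher number from compound 1 to compound 4 (0.79 log units; beyond the scatter). No measurement at hand accounts for these levels.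

The compounds shown leave open whether the high number of compound 2 goes with its pyrazole ring or with its tert-butyl group, which a 1-methyl-1H-pyrazol-4-yl group would test. They also leave open whether a phenyl ring bearing a carboxylic acid or an aminomethyl group in place of the carbamoyl group would stay at the level of compound 3 and compound 4 or approach compound 1.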